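Working notes: methyl to hydrogen on the anilino group

The compounds below may be only part of what the source reports. "The series", "measured", "known", "first", "only" and "open" are said of these compounds alone.

Compound 1 `Cc1ccc(Nc2nc(C)c(C(=O)/C=C/c3ccc(Cl)cc3)s2)cc1`: in a functional assay on NCI-H460 cells (Homo sapiens) for cytotoxicity, read by MTT assay (on this read-out lower numbers stand for stronger inhibition and higher numbers for weaker inhibition), compound 1 gives > 25000 nM, which is a limit of the assay and not a number.
Compound 2 `Cc1ccc(Nc2nc(C)c(C(=O)/C=C/c3ccccc3)s2)cc1`: in this assay compound 2 gives > 25000 nM, again a limit of the assay and not a number.

Going by the values given here, both measured values sit at the same limit, so the only measured step, a step that the two limits leave unreadable from compound 1 to compound 2, cannot be read in either size or direction; all that is known is the limit of > 25000 nM in this assay, at which 2 of the 2 values shown sit. Compound 2 therefore stands at the limit of this assay, with no number of its own.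

Compound 3 `Cc1nc(Nc2ccccc2)sc1C(=O)/C=C/c1ccccc1` differs from compound 2 in one place: hydrogen in place of methyl on an aromatic carbon. Among the compounds with values here, no measured step bears on this change, since the one step recorded concerns the chloro group and is itself unreadable. With two of two values at the limit, no movement beyond the scatter is expected from this change, and the step that the limit leaves unreadable from compound 2 to compound 3 is estimated to be small. Compound 3 is expected to give about 40000 nM in this assay, estimated within 15000 nM to 120000 nM, most likely reported again only as a limit.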

Compound 3, half-maximal inhibitory concentration: > 25000 nM
Compound 3: only a limit was reported; the forecaster's own chance of this, stated with the estimate: 80%; the middle value does not contradict the limit.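

In this assay no step can be read between compound 2 and compound 3, as both results are limits of the assay and not numbers. The compounds shown leave open which change to the shared core, if any, would give a readable value in this assay and what the methyl and chloro groups would then contribute.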